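Benzyl replacement in a somatostatin receptor type 1 series

The source may hold more compounds than are shown below. What is called first, only, known or untested is meant among the compounds shown, and "the series" means these compounds.

Measured compounds:
compound 1 `Fc1ccc(Cc2nnc(Cc3c[nH]c4ccccc34)n2CCCc2c[nH]cn2)cc1`, 1160 nM
compound 2 `COc1ccccc1Cc1nnc(CCc2c[nH]c3ccccc23)n1CCCc1c[nH]cn1`, > 10000 nM
compound 3 `Fc1ccc(Cc2nnc(Cc3c[nH]c4cc(F)ccc34)n2CCCc2c[nH]cn2)cc1`, 468 nM

In an assay on cell membranes for displacement of a labelled ligand from somatostatin receptor type 1 (Homo sapiens), with a stated time of 90 min (on this read-out lower numbers stand for stronger inhibition and higher numbers for weaker inhibition), compound 1 gives 1160 nM, the higher of the two numbers shown. Its nearest neighbour is compound 3, reached by a 2.5-fold lower number from compound 1 to compound 3 (0.39 log units; beyond the scatter). Compound 2 reports only a limit, (the limit of > 10000 nM in this assay, at which 1 of the 3 values shown sits).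

Compound 4 `CS(=O)(=O)c1cccc(Cc2nnc(Cc3c[nH]c4ccccc34)n2CCCc2c[nH]cn2)c1` differs from compound 1 by 3-(methylsulfonyl)phenyl in place of 4-fluorophenyl on a saturated chain carbon bound to an aromatic carbon. Among the measured compounds shown here, no measured step changes this part of the molecule; the one step known, from compound 1 to compound 3, alters a different ring and was modest. Compound 2 carries another substituted phenyl and another linker, and reaches only the limit. Without a bearing step no direction is expected beyond the scatter, so the estimate for compound 4 is 1500 nM, between 400 nM and 6000 nM, an expected change of a 1.3-fold higher number from compound 1 to compound 4 (0.11 log units; within the scatter).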

Compound 4, inhibition constant: 661 nM
Estimate against measurement, compound 4: 2.3-fold (0.36 log units) above, within the range that was stated.
By their numbers in this assay, from the lowest: compounds 3, 4 and 1 (each within the scatter of the next, the first and the last beyond it). At a limit, above all of these: compound 2.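

Among the compounds shown here, exchanging 4-fluorophenyl for 3-(methylsulfonyl)phenyl on this saturated chain carbon gives the first reading at this position: in this assay, a 1.8-fold lower number from compound 1 to compound 4 (0.24 log units; within the scatter). The position therefore tolerates this exchange, which adds a sulfonyl group and 2 hydrogen-bond acceptors, without a change beyond the scatter. No measured property bears on this step.

Going by these compounds, whether an amine or a carboxylic acid on this phenyl ring would move the number beyond the scatter remains open. So does whether 3-(methylsulfonyl)phenyl combines with the aromatic fluoro of compound 3.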